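Cytotoxicity Outlook for a Chlorobenzyl Analogue of Compound 1

The compounds below may be only part of what the source reports. "The series", "measured", "known", "first", "only" and "open" are said of these compounds alone.

Compound 1 `N#Cc1ccccc1CN1C(=O)N(Cc2cccc(F)c2)S(=O)(=O)n2cccc21` was examined in an ADME assay on MT4 cells (Homo sapiens) for cytotoxicity, read by MTT assay, with a stated time of 5 days; on this read-out lower numbers stand for higher toxicity in this test and higher numbers for lower toxicity in this test. In this assay compound 1 gives > 305000 nM, which is a limit of the assay and not a number. Compound 2 `N#Cc1ccccc1CN1C(=O)N(Cc2cccc(Cl)c2)S(=O)(=O)n2cccc21` carries the same core; in this assay compound 2 gives > 293000 nM, again a limit. Compound 3 `N#Cc1ccccc1CN1C(=O)N(Cc2ccccc2)S(=O)(=O)n2cccc21` in this assay gives > 318000 nM, once more a limit. So compound 1 stands at a limit, as do the two others, and no order among the three can be read (the limit of > 293000 nM in this assay, at which 1 of the 3 values shown sits, (the limit of > 305000 nM in this assay, at which 1 of the 3 values shown sits), (the limit of > 318000 nM in this assay, at which 1 of the 3 values shown sits)).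

Compound 4 `O=C1N(Cc2cccc(Cl)c2)c2cccn2S(=O)(=O)N1Cc1cccc(F)c1` differs from compound 1 by 3-chlorophenyl in place of 2-cyanophenyl on a saturated chain carbon bound to an amide-type nitrogen in a ring. The measured steps that bear on this change are a step that the two limits leave unreadable from compound 1 to compound 2, a step that the two limits leave unreadable from compound 1 to compound 3 and a step that the two limits leave unreadable from compound 2 to compound 3; each alters a substituent on an aromatic carbon, and none has a readable size because both of its values are limits. For the measured compounds named here, nothing among the measured compounds therefore points to a change beyond the scatter in this assay, in either direction. The step from compound 1 to compound 4 is expected to be about nil, an at least 1.0-fold lower number from compound 1 to compound 4 (0.00 log units; that floor lies within the scatter). Compound 4 is accordingly expected to give 300000 nM in this assay, within a range from 150000 nM to 600000 nM, most probably reported again only as a limit.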

Compound 4, half-maximal cytotoxic concentration: 208000 nM
Estimate against measurement, compound 4: 1.4-fold (0.16 log units) above, within the range that was stated.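

Among the four compounds shown, only compound 4 gives a measured number rather than a limit: in this assay compound 4 gives 208000 nM, whereas the steps among compounds 1, 2 and 3, which alter a substituent on an aromatic carbon, cannot be read. Placing 3-chlorophenyl in place of 2-cyanophenyl on a saturated chain carbon bound to an amide-type nitrogen in a ring gives an at least 1.4-fold lower number from compound 1 to compound 4 (0.16 log units; that floor lies within the scatter), so this change offers a floor for the step, but that floor does not show a change beyond the scatter. The true size of the step remains unknown because compound 1 gives only a limit of the assay, not a number: the limit of > 305000 nM in this assay, at which 1 of the 4 values shown sits.

The single exchange removes the nitrile and brings in the chlorine together, so the compounds shown do not separate what each of these contributes at this place. Going by these compounds, how an amine or a carboxylic acid on this benzyl ring, or a longer chain in place of the 2-cyanobenzyl group, would read in this assay also remains open.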